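The compounds below may be only part of what the source reports. "The series", "measured", "known", "first", "only" and "open" are said of these compounds alone.

Of the compounds shown here, three sharing one core have been tested in a functional assay on HCT-116 cells (Homo sapiens) for cytotoxicity, read by MTT assay, with a stated time of 72 h; on this read-out higher numbers stand for weaker inhibition and lower numbers for stronger inhibition: compound 1 `C[C@H](Nc1c(C(=O)NCc2ccc(F)cc2)nc(Br)c2cccnc12)c1ccccc1`, compound 2 `O=C(NCc1ccc(F)cc1)c1nc(Br)c2cccnc2c1N1CCNCC1` and compound 3 `CNc1c(C(=O)NCc2ccc(F)cc2)nc(Br)c2cccnc12`. None of them yields a number. Compound 1 reads > 20000 nM, which is a limit. Compound 2 reads > 10000 nM, also a limit. Compound 3 reads > 20000 nM, again a limit, and so it stands at the limit of > 20000 nM in this assay, at which 2 of the 3 values shown sit.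

Compound 4 `CNCCCNc1c(C(=O)NCc2ccc(F)cc2)nc(Br)c2cccnc12` departs from compound 3 by 2-(methylamino)ethyl in place of hydrogen on a saturated chain carbon bound to a nitrogen on an aromatic ring, which turns the methyl into 3-(methylamino)propyl. The measured changes nearest to this one are a step that the two limits leave unreadable from compound 1 to compound 3, a step that the two limits leave unreadable from compound 2 to compound 3 and a step that the two limits leave unreadable from compound 1 to compound 2. Going by the values given here, none of the three has a readable size, so they offer no size to carry over, and they show only that three different amino groups all leave this assay at a limit. A large gain is therefore not expected, only a modest shift toward stronger inhibition. The expected change is an at least 1.3-fold lower number from compound 3 to compound 4 (0.12 log units; that floor lies within the scatter). For compound 4 the estimate is 15000 nM, within an expected range of 4000 nM to 40000 nM.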

Compound 4, half-maximal inhibitory concentration: 9000 nM
The estimate for compound 4 lay 1.7-fold (0.22 log units) above the measured number; measured number inside the range.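

In this assay, going by these compounds alone, the 3-(methylamino)propyl group on the nitrogen gives the first reading in this set that is a number and not a limit, so a change at this place on the shared core can register in the read-out. The result is an at least 2.2-fold lower number from compound 3 to compound 4 (0.34 log units; beyond the scatter) and an at least 2.2-fold lower number from compound 1 to compound 4 (0.34 log units; beyond the scatter), whereas an at least 1.1-fold lower number from compound 2 to compound 4 (0.04 log units; that floor lies within the scatter) does not establish a gain over the piperazin-1-yl group. Nothing measured here speaks to why this chain has that effect.

The compounds shown do not tell whether the gain depends on the terminal methylamino group or on the length of the chain that carries it. A 3-hydroxypropyl group on the same nitrogen, or a longer chain ending in the same amine, would begin to separate the two.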